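The source may hold more compounds than are shown below. What is called first, only, known or untested is meant among the compounds shown, and "the series" means these compounds.

Measured so far in an ADME assay on Caco-2 cells (Homo sapiens) for permeability, in the apical to basolateral direction, at pH 7.4; on this read-out lower numbers stand for lower permeability and higher numbers for higher permeability:

- Compound 1 `Cc1ccc2[nH]c(C(=O)N[C@H]3CN(S(=O)(=O)c4ccccc4)C[C@@H]3C(=O)N[C@H]3CCCNC3)cc2c1` gives 0.04 10^-6 cm/s
- Compound 2 `Cc1ccc2[nH]c(C(=O)N[C@H]3CN(S(=O)(=O)c4ccccc4)C[C@]3(C)C(=O)N[C@H]3CCCNC3)cc2c1` gives 0.035 10^-6 cm/s
- Compound 3 `O=C(N[C@H]1CN(S(=O)(=O)c2ccccc2)C[C@@H]1C(=O)NC[C@@H]1CCCN1)c1cc(-c2ccccc2Cl)on1` gives 0.44 10^-6 cm/s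

Compound 3 stands highest of the three, and its gaps to compound 1 and compound 2 both lie beyond the scatter. Compound 4 `CC(=O)N1CCC[C@H](NC(=O)[C@H]2CN(S(=O)(=O)c3ccccc3)C[C@@H]2NC(=O)c2cc(-c3ccccc3Cl)on2)C1` has not yet been measured. It differs from compound 3 by 1-acetylpiperidin-3-yl in place of (pyrrolidin-2-yl)methyl on an amide-type nitrogen with 1-acetylpiperidin-3-yl in place of (pyrrolidin-2-yl)methyl on an amide-type nitrogen. Going by the values given here, no measured pair shows this swap, so the forecast is a judgement. A modest rise, just beyond the scatter, seems likely. The expected move is a 2.7-fold higher number from compound 3 to compound 4 (0.44 log units; beyond the scatter) in this estimate. For compound 4 the estimated value is 1.2 10^-6 cm/s with an expected range from 0.3 10^-6 cm/s to 5 10^-6 cm/s in the same read-out.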

Compound 4, apparent permeability: 0.75 10^-6 cm/s
Beside the measured number, compound 4's estimate is 1.6-fold (0.20 log units) above it; measured number inside the range.
By their numbers in this assay, from the lowest: compounds 2 and 1 (each within the scatter of the next); then compounds 3 and 4 (each within the scatter of the next).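

In this assay, the amide-type nitrogen takes 1-acetylpiperidin-3-yl in place of (pyrrolidin-2-yl)methyl with a 1.7-fold higher number from compound 3 to compound 4 (0.23 log units; within the scatter). So at this position, the read-out stays within the scatter even though the group gains heavy atoms, has a six-membered rather than a five-membered ring, and loses its hydrogen-bond donor. Nothing available gives a reason for this result. 

From the compounds shown here alone, the ring and the acetyl change together in this single step, so their separate contributions remain open. A 1-methylpiperidin-3-yl group or a chain ending in a carboxylic acid at this position could help separate them.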